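Amino for methyl on the pyridyl ring of compound 3

The source may report more compounds than this note shows. Statements on the series, on what has been measured and on what is new or still open speak of the compounds shown alone.

Compound 1 `Cc1cccnc1-c1cc(F)cc(-n2nnc(-c3ccccn3)n2)c1` gives 24 nM in an assay for binding affinity to metabotropic glutamate receptor 5 (Rattus norvegicus); a higher number here means a weaker inhibitor, a lower number a stronger inhibitor. Compound 2 `Cc1ncccc1-c1cc(F)cc(-n2nnc(-c3ccccn3)n2)c1` gives 45 nM. Compound 3 `Cc1ccncc1-c1cc(F)cc(-n2nnc(-c3ccccn3)n2)c1` gives 2 nM.

Compound 3 stands lowest of the three in this assay. The move from compound 1 to compound 3 is a 12-fold lower number from compound 1 to compound 3 (1.08 log units; beyond the scatter), and that from compound 2 to compound 3 is a 23-fold lower number from compound 2 to compound 3 (1.35 log units; beyond the scatter), both beyond the scatter, while the step of a 1.9-fold higher number from compound 1 to compound 2 (0.27 log units; within the scatter) lies within it. Compound 3 is therefore the strongest binder among the measured set.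

Compound 4 `Nc1ccncc1-c1cc(F)cc(-n2nnc(-c3ccccn3)n2)c1` differs from compound 3 in one place: amino in place of methyl on an aromatic carbon. Going by the values given here, none of the measured steps bears on this change, since all three concern where the ring nitrogen and the methyl sit rather than what group occupies that carbon. The expectation therefore rests on compound 3 alone, with wide uncertainty. Compound 4 is expected to lose some binding, with the step estimated as a 7.5-fold higher number from compound 3 to compound 4 (0.88 log units; beyond the scatter). Compound 4 is estimated at 15 nM, within a range from 3 nM to 80 nM.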

Compound 4, inhibition constant: 20 nM
Compound 4: middle estimate off by 1.3-fold (0.12 log units), on the low side; the measured number falls inside the stated range.
By their numbers in this assay, from the lowest: compound 3; then compounds 4, 1 and 2 (each within the scatter of the next, the first and the last beyond it).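

Placing amino instead of methyl on this carbon, opposite the ring nitrogen, costs binding in this assay, with a 10-fold higher number from compound 3 to compound 4 (1.00 log units; beyond the scatter) as the step, so the methyl of the 4-methylpyridin-3-yl group cannot be exchanged for amino without loss. The change removes the clear lead of compound 3 over compound 1, as a 1.2-fold lower number from compound 1 to compound 4 (0.08 log units; within the scatter) shows, while a smaller margin remains over the other isomer, with a 2.3-fold lower number from compound 2 to compound 4 (0.35 log units; beyond the scatter) as the step. Nothing measured here says what lies behind this loss.

The compounds shown do not tell whether the loss belongs to amino alone or would also follow with a methoxy group, a chlorine atom or a dimethylamino group on this carbon. Also open, going by these compounds, is whether the same exchange would cost as much on the methylpyridyl groups of compound 1 and compound 2.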